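The compounds below may be only part of what the source reports. "The series", "measured", "known", "first", "only" and "open" are said of these compounds alone.

Compound 2 `CN(C)CCn1cnnc1-c1cc(Oc2ccc(NC(=O)N/N=C/c3cc(Br)c(O)c(Br)c3)cc2F)ccn1` holds the higher of the two numbers recorded so far: in a functional assay on NCI-H460 cells (Homo sapiens) for cytotoxicity, read by MTT assay, with a stated time of 72 h (on this read-out lower numbers stand for stronger inhibition and higher numbers for weaker inhibition), compound 2 gives 3760 nM. Its nearest neighbour is compound 1 `CN(C)CCn1cnnc1-c1cc(Oc2ccc(NC(=O)N/N=C/c3ccc(O)c(Br)c3)cc2F)ccn1`, which in this assay gives 430 nM. Among the compounds with values here, the only measured step between them is an 8.7-fold higher number from compound 1 to compound 2 (0.94 log units; beyond the scatter), and that step concerns a bromo in place of a hydrogen on an aromatic carbon. Compound 3 `Cc1cc(/C=N/NC(=O)Nc2ccc(Oc3ccnc(-c4nncn4CCN(C)C)c3)c(F)c2)cc(C)c1O` differs from compound 2 by 4-hydroxy-3,5-dimethylphenyl in place of 3,5-dibromo-4-hydroxyphenyl on a carbon with a double bond to nitrogen. Within the data shown here, no measured step exchanges the dibromo pattern for the dimethyl pattern, so the step from compound 1 to compound 2 is the only guide, and it bears on the change only in part. Because compound 1 without the second bromine gave the lower number 430 nM and methyl is a different group from bromine, a number lying between the two measured compounds is expected, more likely a modest fall than none. Compound 3 is therefore estimated to give about 1200 nM in this assay, within 300 nM to 4500 nM, which is expected to amount to a 3.1-fold lower number from compound 2 to compound 3 (0.50 log units; beyond the scatter).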

Compound 3, half-maximal inhibitory concentration: 2010 nM
Estimate against measurement, compound 3: 1.7-fold (0.22 log units) below; the range from low to high includes it.
By their numbers in this assay, from the lowest: compound 1; then compounds 3 and 2 (each within the scatter of the next).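

In this assay, 4-hydroxy-3,5-dimethylphenyl in place of 3,5-dibromo-4-hydroxyphenyl on a carbon with a double bond to nitrogen gives a 1.9-fold lower number from compound 2 to compound 3 (0.27 log units; within the scatter), so at this position compound 2 and compound 3 cannot be told apart, and the two bromo groups of compound 2 can be exchanged for the two methyl groups of compound 3 without a change that can be read. Set against the 3-bromo-4-hydroxyphenyl group of compound 1, the same dimethyl group gives a 4.7-fold higher number from compound 1 to compound 3 (0.67 log units; beyond the scatter), which shows that the step away from compound 1 is not confined to the dibromo pattern, since among these three compounds both the 3,5-dibromo and the 3,5-dimethyl patterns stand apart from compound 1 by more than the scatter. No measurement is available that bears on why the two patterns give such close numbers.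

The compounds shown leave open whether a single methyl group in place of the bromo group of compound 1 would stay close to compound 1 or move towards compound 3, and what a plain 4-hydroxyphenyl group would give at this position. They also leave open how far the numbers depend on the hydroxy group itself, which a methoxy group or an amine in its place would test.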